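From compound 1 to compound 4: one phenyl for another

This account rests on a few compounds, and the source may have more. Where it says the series, first, only, none or still open, it means among the compounds named here.

Measured compounds, with their readings in a functional assay on MOLT-4 cells (Homo sapiens) for inhibition, read by MTT assay, with a stated time of 72 h; a higher number here means a weaker inhibitor, a lower number a stronger inhibitor:
Compound 1 `COc1cc(NC(C)CCCNC(=O)Nc2cccc(F)c2)c2ncccc2c1` – compound 1 gives 23000 nM.
Compound 2 `COc1cc(NC(C)CCCNC(=O)Nc2ccc(Br)cc2)c2ncccc2c1` – compound 2 gives 25000 nM.
Compound 3 `COc1cc(NC(C)CCCNC(=O)NNC(=O)Nc2ccc(Br)cc2)c2ncccc2c1` – compound 3 gives 209000 nM.

Compound 1 holds the lowest of the three numbers. Compound 2 is indistinguishable from it, the step being a 1.1-fold higher number from compound 1 to compound 2 (0.04 log units; within the scatter). Compound 3 stands clearly apart: a 9.1-fold higher number from compound 1 to compound 3 (0.96 log units; beyond the scatter), and likewise an 8.4-fold higher number from compound 2 to compound 3 (0.92 log units; beyond the scatter).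

Compound 4 `COc1cc(NC(C)CCCNC(=O)Nc2ccc(C(F)(F)F)cc2)c2ncccc2c1` is not yet measured. Its difference from compound 1 is 4-(trifluoromethyl)phenyl in place of 3-fluorophenyl on an amide-type nitrogen.

Going by the values given here, only one measured step bears on this change. Going from compound 1 to compound 2 also swapped one substituted phenyl on the amide-type nitrogen for another, and that step stayed within the scatter. The two steps into compound 3 involve a different kind of change, the insertion of a ((4-bromophenyl)carbamoyl)amino group, and offer no guidance on a phenyl exchange.

Compound 4 is therefore expected to show no step beyond the scatter in this assay, the estimated step being a 1.1-fold higher number from compound 1 to compound 4 (0.04 log units; within the scatter). For compound 4 the estimate in this assay is 25000 nM, with a range from 10000 nM to 60000 nM.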

Compound 4, half-maximal inhibitory concentration: 20000 nM
The estimate for compound 4 lay 1.3-fold (0.10 log units) above the measured number; low and high end bracket the measured number.
By their numbers in this assay, from the lowest: compounds 4, 1 and 2 (each within the scatter of the next); then compound 3.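

In this assay, the exchange of 3-fluorophenyl for 4-(trifluoromethyl)phenyl on the amide-type nitrogen gives a 1.2-fold lower number from compound 1 to compound 4 (0.06 log units; within the scatter), so this position has now tolerated a second exchange of one substituted phenyl for another without a step beyond the scatter. The new compound also allows a comparison that the earlier ones did not, trifluoromethyl in place of bromo on an aromatic carbon, and this gives a 1.3-fold lower number from compound 2 to compound 4 (0.10 log units; within the scatter), so the two substituents cannot be told apart in this assay. The gap to the compound carrying ((4-bromophenyl)carbamoyl)amino remains, at a 10-fold lower number from compound 3 to compound 4 (1.02 log units; beyond the scatter), and among the four compounds that group alone is set apart by a step beyond the scatter.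

Nothing available here accounts for the similar readings of the three phenyl compounds or for the distance of compound 3 from them. As far as these compounds go, it remains open whether a phenyl carrying an amine or a carboxylic acid, a cyclohexyl group in place of the phenyl, or a longer chain on the shared core would move the number beyond the scatter.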